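This account rests on a few compounds, and the source may have more. Where it says the series, first, only, none or still open, it means among the compounds named here.

Compound 1 `CCc1cc(Cl)c(S(C)(=O)=O)cc1C(=O)N=C(N)N` and compound 2 `CCc1cc(Br)c(S(C)(=O)=O)cc1C(=O)N=C(N)N` share a core that carries an ethyl group, and compound 3 `CS(=O)(=O)c1cc(C(=O)N=C(N)N)ccc1Oc1cccnc1` carries a (pyridin-3-yl)oxy group in place of a halogen and a hydrogen where the others carry ethyl. In a functional assay for inhibition of sodium/hydrogen exchanger (Oryctolagus cuniculus) (a higher number here means a weaker inhibitor, a lower number a stronger inhibitor), compound 1 gives 63 nM, compound 2 gives 41 nM, and compound 3 gives 76 nM. Among the measured compounds shown here, the one single-point step among them, a 1.5-fold lower number from compound 1 to compound 2 (0.19 log units; within the scatter), stays within the scatter. Compound 3 has the highest of the three numbers, but its gaps to compound 1 and to compound 2 are both within the scatter, so no order among the three can be read from them. Compound 4 `CCc1cc(Oc2cccnc2)c(S(C)(=O)=O)cc1C(=O)N=C(N)N` differs from compound 3 by ethyl in place of hydrogen on an aromatic carbon. For the measured compounds named here, no measured pair isolates this change: compound 1 and compound 2 carry the ethyl group alongside a halogen, never alongside the (pyridin-3-yl)oxy group, and the halogen swap between them tells nothing about ethyl against hydrogen. Compound 4 is therefore expected to show a 1.4-fold lower number from compound 3 to compound 4 (0.14 log units; within the scatter), a step of no clear size in this assay, and its estimate is 55 nM, between 20 nM and 150 nM.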

Compound 4, half-maximal inhibitory concentration: 27 nM
Compound 4: middle estimate off by 2.0-fold (0.31 log units), on the high side; low and high end bracket the measured number.
By their numbers in this assay, from the lowest: compounds 4, 2, 1 and 3 (each within the scatter of the next, the first and the last beyond it).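

In this assay, among the compounds shown here, ethyl in place of hydrogen on this aromatic carbon, with the (pyridin-3-yl)oxy group present, gives a 2.8-fold lower number from compound 3 to compound 4 (0.45 log units; beyond the scatter) as the first reading of this change, a modest step beyond the scatter. On the ethyl-bearing core, (pyridin-3-yl)oxy in place of chloro gives a 2.3-fold lower number from compound 1 to compound 4 (0.37 log units; beyond the scatter) and is thus separated from chloro, whereas in place of bromo it gives a 1.5-fold lower number from compound 2 to compound 4 (0.18 log units; within the scatter) and is not separated from bromo. Nothing measured here accounts for the ethyl step.

On these data alone, whether ethyl in place of hydrogen gives a step of similar size alongside chloro or bromo remains open, as neither halogen has a partner carrying hydrogen here. Also open, as far as these compounds go, is how a longer chain such as propyl, or an amine, would read on this same aromatic carbon.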